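The source may hold more compounds than are shown below. What is called first, only, known or untested is meant among the compounds shown, and "the series" means these compounds.

Among the compounds with values here, compound 1 `COC(=O)N[C@H](C(=O)N1CCC[C@H]1C(=O)Nc1ccc([C@@H]2CC[C@@H](c3ccc(NC(=O)[C@@H]4CCCN4C(=O)[C@@H](NC(=O)OC)[C@@H](C)OC)cc3)N2c2ccc(F)cc2)cc1)[C@@H](C)OC` is one of three compounds measured here. In an ADME assay on the whole organism (plasma) for pharmacokinetics, with Rattus norvegicus as the target, at a dose of 3 mg/kg by the oral route (on this read-out higher numbers stand for higher exposure at the dose given and lower numbers for lower exposure), compound 1 gives 120 ng.h/mL, the lowest of the three numbers. Compound 2 `COC(=O)N[C@H](C(=O)N1CCC[C@H]1C(=O)Nc1ccc([C@@H]2CC[C@@H](c3ccc(NC(=O)[C@@H]4CCCN4C(=O)[C@@H](NC(=O)OC)C(C)C)cc3)N2c2ccc(F)cc2)cc1)C(C)C` gives 750 ng.h/mL in this assay, and compound 3 `COC(=O)N[C@H](C(=O)N1CCC[C@H]1C(=O)Nc1ccc([C@H]2CC[C@H](c3ccc(NC(=O)[C@@H]4CCCN4C(=O)[C@@H](NC(=O)OC)C(C)C)cc3)N2c2ccc(F)cc2)cc1)C(C)C` gives 6360 ng.h/mL. Within the data shown here, the only measured step that mirrors the change of interest is an 8.5-fold higher number from compound 2 to compound 3 (0.93 log units; beyond the scatter), a rise that rests on (the fact that compounds 2 and 3 differ only in the configuration as drawn). Compound 4 `COC(=O)N[C@H](C(=O)N1CCC[C@H]1C(=O)Nc1ccc([C@H]2CC[C@H](c3ccc(NC(=O)[C@@H]4CCCN4C(=O)[C@@H](NC(=O)OC)[C@@H](C)OC)cc3)N2c2ccc(F)cc2)cc1)[C@@H](C)OC` relates to compound 1 in the same way: the two compounds have the same atoms and bonds and differ only in configuration as drawn: 2 of 8 stereo elements differ; a stereocentre at a saturated ring carbon is drawn S in compound 1 and R in compound 4; a stereocentre at a saturated ring carbon is drawn S in compound 1 and R in compound 4. Since this is the same kind of change, a rise of a similar size, well beyond the scatter, is expected in this assay. Compound 4 is therefore estimated to give 1000 ng.h/mL, with a range from 300 ng.h/mL to 3500 ng.h/mL. The expected step is an 8.3-fold higher number from compound 1 to compound 4 (0.92 log units; beyond the scatter).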

Compound 4, area under the concentration-time curve: 170 ng.h/mL
The estimate for compound 4 lay 5.9-fold (0.77 log units) above the measured number, and the stated range ends above it.
By their numbers in this assay, from the lowest: compounds 1 and 4 (each within the scatter of the next); then compound 2; then compound 3.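

In this assay, inverting the same two saturated ring carbons gives a 1.4-fold higher number from compound 1 to compound 4 (0.15 log units; within the scatter), whereas the earlier pair gave an 8.5-fold higher number from compound 2 to compound 3 (0.93 log units; beyond the scatter). The effect of this configuration therefore does not carry over from one pair to the other. Within the data shown here, it appears to depend on the side chains, the one feature that separates the two pairs, although each pair offers only a single comparison.

From the compounds shown here alone, how other side chains respond remains open. With a tert-butyl group in their place, the compounds shown cannot tell whether inverting these ring carbons would give a large step or none beyond the scatter.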